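Chloro-to-ester swap on the aryl cyanoguanidine arm

The source may report more compounds than this note shows. Statements on the series, on what has been measured and on what is new or still open speak of the compounds shown alone.

Measured so far:
compound 1, `CC1(C)Oc2ccc(C#N)cc2[C@@H](/N=C(\NC#N)Nc2ccc(Cl)cc2)[C@@H]1O`, 1800 nM
compound 2, `CC1(C)Oc2ccc(C#N)cc2[C@@H](NC(=O)Nc2ccccc2)[C@@H]1O`, 800 nM

Of the compounds shown here, two have been tested in a functional assay (aorta) with Rattus norvegicus as the target; a higher number here means a weaker inhibitor, a lower number a stronger inhibitor. Compound 1 gives 1800 nM and compound 2 gives 800 nM. Within these two numbers compound 1 stands highest, with a difference to compound 2 that lies beyond the usual scatter. Compound 1 and compound 2 differ in more than one place, so no single step can be read from them.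

Compound 3, `COC(=O)c1ccc(N/C(=N/[C@@H]2c3cc(C#N)ccc3OC(C)(C)[C@H]2O)NC#N)cc1`, is not yet measured. It comes from compound 1 by the change (methoxycarbonyl in place of chloro on an aromatic carbon), that is, methoxycarbonyl in place of chloro on an aromatic carbon of a six-membered aromatic ring of carbon only. Within the data shown here, no measured pair shows the effect of this change, so the direction is open. The expectation for a 1.4-fold higher number from compound 1 to compound 3 (0.14 log units; within the scatter) is a step no larger than the scatter, if anything towards a weaker inhibitor. Compound 3 is therefore estimated at 2500 nM, with a range from 800 nM to 8000 nM.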

Compound 3, half-maximal inhibitory concentration: 18400 nM
Compound 3: the middle estimate sits 7.4-fold (0.87 log units) below what was measured; measured number above the stated range.
By their numbers in this assay, from the lowest: compound 2; then compound 1; then compound 3.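

In this assay, among these compounds, the change from 4-chlorophenyl to 4-(methoxycarbonyl)phenyl gives the only single-place step, and that step is large: a 10-fold higher number from compound 1 to compound 3 (1.01 log units; beyond the scatter), beyond the scatter. This place on the aromatic carbon, para to a large group, therefore does not tolerate every replacement of chloro, since methoxycarbonyl, which brings 4 heavy atoms and 2 hydrogen-bond acceptors where chloro had 1 heavy atom and none, goes with a much weaker inhibitor. Nothing at hand bears on the reason for this rise in the number.

Going by these compounds, whether the loss belongs to the ester itself or to any replacement with more heavy atoms stays open, and a carboxylic acid, a primary amide, a methyl or a methoxy on the same aromatic carbon would help to separate these readings. Steps involving compound 2 cannot be read, as it differs from the other compounds in more than one place, so it also remains open whether methoxycarbonyl would have the same effect on its urea arm.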